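The compounds below may be only part of what the source reports. "The series", "measured", "known", "first", "only" and "open" are said of these compounds alone.

Measured compounds in an ADME assay on MT4 cells (Homo sapiens) for cytotoxicity, read by MTT assay; a lower number here means that less compound is tolerated, a higher number that more compound is tolerated:

compound 1 `O=C1c2ccccc2C(=O)N1CCOC(=S)N(C(=O)c1ccc(Cl)cc1Cl)c1ccc(Cl)cc1`: 18000 nM
compound 2 `O=C1c2ccccc2C(=O)N1CCOC(=S)N(C(=O)c1c(Cl)cccc1Cl)c1ccc(Cl)cc1`: 20000 nM
compound 3 `Cc1ccc(N(C(=O)c2ccc(Cl)cc2Cl)C(=S)OCCN2C(=O)c3ccccc3C2=O)cc1`: 49000 nM

Compound 4 `Cc1ccc(N(C(=O)c2c(Cl)cccc2Cl)C(=S)OCCN2C(=O)c3ccccc3C2=O)cc1` has not yet been measured in this assay. It differs from compound 3 by a single exchange, (2,6-dichlorophenyl in place of 2,4-dichlorophenyl on a carbonyl carbon). The same exchange is already covered by one measured pair: compound 2 differs from compound 1 by 2,6-dichlorophenyl in place of 2,4-dichlorophenyl on a carbonyl carbon, and in this assay that pair gives a 1.1-fold higher number from compound 1 to compound 2 (0.05 log units; within the scatter). The two "place" descriptions are identical word for word, so this is the same change, made on a different core. The two cores differ by methyl in place of chloro on an aromatic carbon, which in this assay gives a 2.7-fold higher number from compound 1 to compound 3 (0.43 log units; beyond the scatter); compound 3 stands highest of the three measured numbers, and its gap to compound 2 is also beyond the scatter.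

Within the data shown here, with only one prior example of the exchange, the expectation for compound 4 rests on that single pair. Among the measured compounds shown here, the step from compound 3 to compound 4 in this assay is expected to be a 1.1-fold higher number from compound 3 to compound 4 (0.03 log units; within the scatter), set beside the measured step of a 1.1-fold higher number from compound 1 to compound 2 (0.05 log units; within the scatter), since that is the only guide available. Whether the change in core between compound 1 and compound 3 alters the effect of the exchange cannot be judged from these three compounds alone, so the range is kept wide.

Compound 4 is therefore estimated at 52000 nM in this assay, with the range 28000 nM to 95000 nM.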

Compound 4, half-maximal cytotoxic concentration: 22000 nM
Compound 4: middle estimate off by 2.4-fold (0.37 log units), on the high side; measured number below the stated range.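

In this assay, 2,6-dichlorophenyl in place of 2,4-dichlorophenyl on a carbonyl carbon gives a 2.2-fold lower number from compound 3 to compound 4 (0.35 log units; beyond the scatter), whereas on the core of compound 1 the same exchange gave a 1.1-fold higher number from compound 1 to compound 2 (0.05 log units; within the scatter), yet these two steps cannot be told apart: the same change on two cores in this assay, a 1.1-fold higher number (0.05 log units; within the scatter) from compound 1 to compound 2 and a 2.2-fold lower number (0.35 log units; beyond the scatter) from compound 3 to compound 4, 2.5-fold (0.39 log units) apart, within the scatter of two such steps
The methyl in place of chloro exchange reads the same way, since its new step is a 1.1-fold higher number from compound 2 to compound 4 (0.04 log units; within the scatter) against the earlier 2.7-fold higher number from compound 1 to compound 3 (0.43 log units; beyond the scatter), and again the two cannot be separated: the same change on two cores in this assay, a 2.7-fold higher number (0.43 log units; beyond the scatter) from compound 1 to compound 3 and a 1.1-fold higher number (0.04 log units; within the scatter) from compound 2 to compound 4, 2.5-fold (0.39 log units) apart, within the scatter of two such steps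
Among these compounds, these four compounds therefore show no firm difference in how either exchange carries from one core to the other, but they do not show that it carries unchanged, as each exchange rests on only two steps and the step from compound 3 to compound 4 alone lies beyond the scatter.

Still open, from the compounds shown here alone, is whether a dichlorophenyl exchange behaves alike when the methyl or chloro group is replaced by another group, such as an amine or a carboxylic acid. Also open, going by these compounds, is whether tolerance in this cell assay follows the same course with a longer chain on the amide-type nitrogen, or with a single chloro group on the phenyl ring of the carbonyl.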